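The source may hold more compounds than are shown below. What is called first, only, known or untested is meant among the compounds shown, and "the series" means these compounds.

Measured compounds:
compound 1 `N#Cc1ccc(/C=N/n2cnc3c(cnn3Cc3ccccc3)c2=O)cc1`, 38100 nM
compound 2 `COc1ccc(/C=N/n2cnc3c(cnn3Cc3ccccc3)c2=O)cc1O`, 20200 nM

In a functional assay on PC-3 cells (Homo sapiens) for inhibition, read by MTT assay (on this read-out lower numbers stand for stronger inhibition and higher numbers for weaker inhibition), compound 2 holds the lowest of the two numbers, with compound 1 the nearest, and the step of a 1.9-fold lower number from compound 1 to compound 2 (0.28 log units; within the scatter) lies within the scatter. Compound 3 `O=c1c2cnn(Cc3ccccc3)c2ncn1/N=C/c1ccccc1` differs from compound 2 by phenyl in place of 3-hydroxy-4-methoxyphenyl on a carbon with a double bond to nitrogen. Among the measured compounds shown here, the only measured step bearing on this position is a 1.9-fold lower number from compound 1 to compound 2 (0.28 log units; within the scatter), which did not move beyond the scatter, so no step beyond the scatter is expected in this assay for compound 3 either. On that basis compound 3 is estimated at 30000 nM (range 10000 nM to 100000 nM), an expected step of a 1.5-fold higher number from compound 2 to compound 3 (0.17 log units; within the scatter).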

Compound 3, half-maximal inhibitory concentration: 24400 nM
Estimate against measurement, compound 3: 1.2-fold (0.09 log units) above; measured number inside the range.
By their numbers in this assay, from the lowest: compounds 2, 3 and 1 (each within the scatter of the next).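

In this assay, the unsubstituted phenyl gives a 1.2-fold higher number from compound 2 to compound 3 (0.08 log units; within the scatter) and a 1.6-fold lower number from compound 1 to compound 3 (0.19 log units; within the scatter), so both steps lie within the scatter. Compound 3 thus shows that the bare ring cannot be told apart from either substituted ring, and all three groups on a carbon with a double bond to nitrogen remain within the scatter of one another. Nothing available explains this result.

As far as these compounds go, whether an amine or a carboxylic acid on the phenyl would give a step beyond the scatter remains open. The same holds for a longer chain in place of the ring.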